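This account rests on a few compounds, and the source may have more. Where it says the series, first, only, none or still open, it means among the compounds named here.

Compound 1 `COc1cc(OCc2cccc(CCc3ccccc3)c2)c2cc(-c3cn4nc(OC)sc4n3)oc2c1`: 99%
Compound 2 `COc1cc(OCc2cccc(Sc3ccccc3)c2)c2cc(-c3cn4nc(OC)sc4n3)oc2c1`: 80%
Compound 3 `COc1cc(OCc2cccc(Oc3ccccc3)c2)c2cc(-c3cn4nc(OC)sc4n3)oc2c1`: 86%

In an ADME assay on microsomes from liver (Homo sapiens) for metabolic stability, with a stated time of 10 min (on this read-out higher numbers stand for a more stable compound and lower numbers for a less stable compound), compound 3 gives 86%, the second highest of the three numbers; the nearer step is a number 6 percentage points higher from compound 2 to compound 3 (within the scatter), the further one is a number 13 percentage points lower from compound 1 to compound 3 (beyond the scatter). Compound 4 `COc1cc(OCc2cccc(OCc3ccccc3)c2)c2cc(-c3cn4nc(OC)sc4n3)oc2c1` differs from compound 3 by benzyl in place of phenyl on an oxygen on an aromatic ring. The measured steps all concern the link between the two outer aromatic rings: a number 19 percentage points lower from compound 1 to compound 2 (beyond the scatter) and a number 13 percentage points lower from compound 1 to compound 3 (beyond the scatter) were modest losses, and a number 6 percentage points higher from compound 2 to compound 3 (within the scatter) stayed within the scatter. None of them adds a benzyl to an oxygen, so for compound 4 only a small step is expected, a number 2 percentage points higher from compound 3 to compound 4 (within the scatter), within the scatter. Compound 4 is therefore estimated at 88%, between 72% and 99%.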

Compound 4, percent of the compound remaining: 85%
Beside the measured number, compound 4's estimate is 3 percentage points above it; low and high end bracket the measured number.
By their numbers in this assay, from the lowest: compounds 2, 4 and 3 (each within the scatter of the next); then compound 1.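

In this assay, benzyl in place of phenyl on this oxygen makes no clear difference, a number 1 percentage points lower from compound 3 to compound 4 (within the scatter), and benzyloxy is also not separated from phenylsulfanyl, a number 5 percentage points higher from compound 2 to compound 4 (within the scatter). The gap to phenethyl remains, a number 14 percentage points lower from compound 1 to compound 4 (beyond the scatter), so the extra carbon in the oxygen link does not recover the number of compound 1. No evidence here explains these numbers. On these data alone, it remains open how this assay would respond to an amine or a carboxylic acid carried on the chain in place of the benzyl.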